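Carbamoylmethyl to allyl on the sulfur side chain

The compounds below may be only part of what the source reports. "The series", "measured", "known", "first", "only" and "open" are said of these compounds alone.

Of the compounds shown here, three sharing one core have been measured in a functional assay on HT cells (Homo sapiens) for antiproliferative activity, read by fluorescence, with a stated time of 72 h; a higher number here means a weaker inhibitor of growth, a lower number a stronger inhibitor of growth. There compound 1 `CC(C)c1n[nH]c2c(NCc3ccc(-c4ccccn4)cc3)nc(SCC(O)CO)nc12` gives 21 nM, compound 2 `CC(C)c1n[nH]c2c(NCc3ccc(-c4ccccn4)cc3)nc(SCC(O)CN3CCNCC3)nc12` gives 332 nM and compound 3 `CC(C)c1n[nH]c2c(NCc3ccc(-c4ccccn4)cc3)nc(SCC(N)=O)nc12` gives 192 nM. Compound 3 thus holds the middle number of the three, although it cannot be separated from its nearest neighbour: a 1.7-fold lower number from compound 2 to compound 3 (0.24 log units; within the scatter).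

Compound 4 `C=CCSc1nc(NCc2ccc(-c3ccccn3)cc2)c2[nH]nc(C(C)C)c2n1` keeps the core and alters only the chain on sulfur: vinyl in place of carbamoyl on a saturated chain carbon bound to a sulfur. In words, this is vinyl in place of carbamoyl on a saturated chain carbon bound to a sulfur. For the measured compounds named here, no measured step makes this exact change. The nearest evidence is other changes to the same chain, which moved the number clearly: a 9.1-fold higher number from compound 1 to compound 3 (0.96 log units; beyond the scatter) and a 16-fold higher number from compound 1 to compound 2 (1.20 log units; beyond the scatter). Those steps show that this chain matters but do not fix a direction for an allyl group, so only a small to modest lowering in this assay is expected. The expected change is a 2.1-fold lower number from compound 3 to compound 4 (0.33 log units; beyond the scatter). For compound 4 the estimated value is 90 nM, within an expected range of 30 nM to 270 nM.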

Compound 4, concentration for 50% growth inhibition: 1010 nM
Estimate against measurement, compound 4: 11-fold (1.05 log units) below; measured number outside the range, above it.
By their numbers in this assay, from the lowest: compound 1; then compounds 3 and 2 (each within the scatter of the next); then compound 4.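

In this assay, allyl on sulfur proved the weakest of the four chains, with a 5.3-fold higher number from compound 3 to compound 4 (0.72 log units; beyond the scatter) and so a clear drop from the carbamoylmethyl chain. Compounds 2 and 3 themselves cannot be separated. Compound 4 also stands apart from the piperazine-bearing chain, with a 3.0-fold higher number from compound 2 to compound 4 (0.48 log units; beyond the scatter), and the widest gap is to the diol, with a 48-fold higher number from compound 1 to compound 4 (1.68 log units; beyond the scatter) as the largest step in the set. Allyl, with no hydrogen-bond donors or acceptors, is thus the only chain here without oxygen or nitrogen and gives the weakest inhibition of growth, so among these four compounds, a heteroatom-free chain on sulfur comes with the poorest result.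

Nothing measured here explains this loss. Going by these compounds, it remains open whether a carboxylic acid, a simple primary amine or a longer saturated carbon chain on sulfur would fall nearer compound 1 or compound 4.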